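The compounds below may be only part of what the source reports. "The series", "measured", "known", "first", "only" and "open" are said of these compounds alone.

Measured so far in a functional assay on CCRF-CEM cells (Homo sapiens) for antiproliferative activity, read by sulforhodamine B assay, with a stated time of 48 h; on this read-out higher numbers stand for weaker inhibition and lower numbers for stronger inhibition:
- compound 1 `O=C1NCCN1c1ccc(S(=O)(=O)Nc2cccc(Br)c2)cc1` gives 110 nM
- compound 2 `Cc1cc(C)cc(NS(=O)(=O)c2ccc(N3CCNC3=O)cc2)c1` gives 170 nM

Going by the values given here, compound 2 is one of only two numbers; its sole neighbour, compound 1, sits within the scatter of it, the step of a 1.5-fold higher number from compound 1 to compound 2 (0.19 log units; within the scatter) being too small to separate the two. The unmeasured compound 3 `Cc1cccc(NS(=O)(=O)c2ccc(N3CCNC3=O)cc2)c1` differs from compound 2 by hydrogen in place of methyl on an aromatic carbon, that is, 3,5-dimethylphenyl becomes 3-methylphenyl on the sulfonamide nitrogen. Among the compounds with values here, no measured pair shows exactly this change. Within the data shown here, the only step available, a 1.5-fold higher number from compound 1 to compound 2 (0.19 log units; within the scatter), exchanged a 3-bromophenyl for a 3,5-dimethylphenyl and stayed within the scatter, which suggests the group on the sulfonamide nitrogen is not read tightly by this assay. Compound 3 is therefore expected to give 200 nM (range 90 nM to 450 nM), an estimated step of a 1.2-fold higher number from compound 2 to compound 3 (0.07 log units; within the scatter) that would not clearly exceed the scatter.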

Compound 3, half-maximal inhibitory concentration: 200 nM
Compound 3: middle estimate and measured number agree at the digits printed; the measured number falls inside the stated range.
By their numbers in this assay, from the lowest: compounds 1, 2 and 3 (each within the scatter of the next).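

In this assay, the step of a 1.2-fold higher number from compound 2 to compound 3 (0.07 log units; within the scatter) stays within the scatter, so the second methyl of the 3,5-dimethylphenyl group makes no readable difference in this pair. With a 1.8-fold higher number from compound 1 to compound 3 (0.26 log units; within the scatter) as the step for methyl in place of bromo on an aromatic carbon, the 3-methylphenyl and 3-bromophenyl compounds cannot be separated either, and across compounds 1, 2 and 3 these changes on the sulfonamide nitrogen's aromatic ring leave the read-out flat within the scatter. Nothing available explains this flatness.

Still open, going by these compounds, is how a methoxy group, an amine or a carboxylic acid on this aromatic carbon would read, and how a plain phenyl would compare. On these data alone, whether any change at this position can step beyond the scatter in this assay also remains unknown.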